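Swapping Ethyl for Cyano on a Shared Core

A few compounds are considered here, and "the series" means these few. Any claim that something is new, unique, unknown or untested is made for them only; others in the source may bear on it.

Compound 1, with the structure `CCc1ccc(-c2nc3ccccn3c2Sc2ccccc2)cc1`, was tested in an ADME assay on NIH3T3 cells (Mus musculus) for inhibition, read by MTT assay, with a stated time of 48 h; on this read-out higher numbers stand for weaker inhibition and lower numbers for stronger inhibition. In this assay compound 1 gives > 100000 nM, which is a limit of the assay rather than a measured number. Compound 2, with the structure `c1ccc(Sc2c(-c3ccccc3)nc3ccc(-c4ccccc4)cn23)cc1`, likewise gives > 100000 nM in this assay, again a limit. Both compounds therefore sit at the limit of > 100000 nM in this assay, at which 2 of the 2 values shown sit, so compound 1 has no numerical position at all on the values shown; it stands at the limit together with compound 2.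

Compound 3 has the structure `N#Cc1ccc(-c2nc3ccccn3c2Sc2ccccc2)cc1` and has not yet been measured in this assay. It differs from compound 1 in a single place: cyano in place of ethyl on an aromatic carbon

Among the measured compounds shown here, no measured step between two compounds is available here, so the expectation rests on the values shown alone. Compound 1 gives > 100000 nM in this assay, a limit. Compound 3 is expected to show no step beyond the usual scatter, an estimated change of a number no higher from compound 1 to compound 3 (the limit leaves the size open). Compound 3 is therefore estimated at 100000 nM, within a range from 30000 nM to 300000 nM, and this assay will most likely report only a limit once more.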

Compound 3, half-maximal inhibitory concentration: > 100000 nM
Compound 3 ended at the assay's limit (the forecaster's own chance of this, stated with the estimate: 75%); the middle value sits exactly at the limit.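

No step can be read from compound 1 to compound 3, because both give only a limit rather than a measured number in this assay: the limit of > 100000 nM in this assay, at which 3 of the 3 values shown sit.

The compounds shown leave open whether cyano in place of ethyl changes inhibition at all, and which change to the shared core, if any, would give a measured number.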